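Alkynyl Series: Replacing 4-Methoxyphenyl with Pyridin-2-yl

The source may hold more compounds than are shown below. What is called first, only, known or untested is meant among the compounds shown, and "the series" means these compounds.

Measured in a functional assay on MCF7 cells (Homo sapiens) for inhibition, read by sulforhodamine B assay, with a stated time of 48 h; on this read-out lower numbers stand for stronger inhibition of growth and higher numbers for weaker inhibition of growth:
compound 1 `COC(=O)c1sc2cc(C#Cc3ccc(OC)cc3)cnc2c1N`: 460 nM
compound 2 `COC(=O)c1sc2cc(C#Cc3ccc(F)cc3)cnc2c1N`: 29000 nM
compound 3 `COC(=O)c1sc2cc(C#Cc3ccsc3)cnc2c1N`: 27700 nM

Compound 1 has the lowest number of the three. Compound 4 `COC(=O)c1sc2cc(C#Cc3ccccn3)cnc2c1N` differs from it by pyridin-2-yl in place of 4-methoxyphenyl on a triple-bonded carbon. Within the data shown here, two measured steps bear on this, both leaving the same position of compound 1: a 63-fold higher number from compound 1 to compound 2 (1.80 log units; beyond the scatter), and a 60-fold higher number from compound 1 to compound 3 (1.78 log units; beyond the scatter). Compounds 2 and 3 sit together, a 1.0-fold lower number from compound 2 to compound 3 (0.02 log units; within the scatter). Every measured departure from 4-methoxyphenyl at the triple-bonded carbon therefore brought a large rise in this assay, and a rise of comparable size is expected for compound 4. The expected step is a 20-fold higher number from compound 1 to compound 4 (1.29 log units; beyond the scatter). Compound 4 is estimated at 9000 nM, within 1500 nM to 45000 nM.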

Compound 4, concentration for 50% growth inhibition: 37400 nM
Compound 4: the middle estimate sits 4.2-fold (0.62 log units) below what was measured; the measured number falls inside the stated range.
By their numbers in this assay, from the lowest: compound 1; then compounds 3, 2 and 4 (each within the scatter of the next).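

In this assay, pyridin-2-yl in place of 4-methoxyphenyl on the triple-bonded carbon also gives a large rise (an 81-fold higher number from compound 1 to compound 4 (1.91 log units; beyond the scatter)), so a third replacement, this one with a ring nitrogen, fails to keep the number of compound 1. Pyridin-2-yl does not separate from the other two replacements (a 1.4-fold higher number from compound 3 to compound 4 (0.13 log units; within the scatter); a 1.3-fold higher number from compound 2 to compound 4 (0.11 log units; within the scatter)). No measurement at hand bears on why these steps occur. Open, on these data alone, is whether the low number of compound 1 needs methoxy itself. A phenyl carrying hydroxy, ethoxy or dimethylamino in its place would test this.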